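Swapping Chloro for Methyl on an Imidazoline Agonist

The compounds below may be only part of what the source reports. "The series", "measured", "known", "first", "only" and "open" are said of these compounds alone.

Of the compounds shown here, three built on a shared core have been measured in a functional assay on CHO cells for agonist activity at Alpha-2C adrenergic receptor (Homo sapiens); a higher number here means a larger maximal response, a lower number a smaller maximal response. Compound 1 `CS(=O)(=O)c1cc(Cl)ccc1NCC1=NCCN1` gives 54% in this assay. Compound 2 `CSc1ccc(F)cc1NCC1=NCCN1` gives 97%. Compound 3 `CS(=O)(=O)c1ccc(Cl)cc1NCC1=NCCN1` gives 81%, the second highest of the three numbers; its gap to compound 2, which lies higher, and its gap to compound 1, which lies lower, are both beyond the usual scatter of repeated measurements.

Compound 4 `Cc1ccc(S(C)(=O)=O)c(NCC2=NCCN2)c1` has not yet been measured. It differs from compound 3 in a single place: methyl in place of chloro on an aromatic carbon. For the measured compounds named here, none of the three measured compounds differ from one another in only one place, so no measured step shows directly what such a swap does to the maximal response.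

Since the group that leaves and the group that enters are of the same size and neither carries a donor, an acceptor or a charge, the maximal response of compound 4 is expected to stay near that of compound 3. The step expected here, a number 3 percentage points lower from compound 3 to compound 4 (within the scatter), falls within the scatter. Compound 4 is estimated to give 78% in this assay, with a range from 55% to 98%.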

Compound 4, largest response reached (reported as maximum), in percent of the reference or control that the assay uses: 76%
Compound 4: the middle estimate sits 2 percentage points above what was measured, within the range that was stated.
By their numbers in this assay, from the lowest: compound 1; then compounds 4 and 3 (each within the scatter of the next); then compound 2.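

For the compounds shown here, the swap of chloro for methyl is the first change that can be read on its own, because compounds 3 and 4 differ in only this one place. In this assay, it gives a number 5 percentage points lower from compound 3 to compound 4 (within the scatter), so at this aromatic carbon, para to a methylsulfonyl group, the maximal response does not separate the two groups. No measurement shown here offers an explanation for this match.

As far as these compounds go, only these two groups have been compared at this carbon, so it remains open whether an amine, a carboxylic acid or a longer chain placed there would also leave the maximal response unchanged. From the compounds shown here alone, it is also open whether the same swap of chloro for methyl would have so small an effect at another carbon of that ring.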